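The source may report more compounds than this note shows. Statements on the series, on what has been measured and on what is new or still open speak of the compounds shown alone.

Measured compounds:
Compound 1 `COc1ccc(C2C(C#N)=C(N)N(c3cc(OC)c(OC)c(OC)c3)C3=C2C(=O)CC(C)(C)C3)cc1` — "not active" (no number reported)
Compound 2 `COc1cc(N2C(N)=C(C#N)C(c3cccc([N+](=O)[O-])c3)C3=C2CC(C)(C)CC3=O)cc(OC)c1OC` — "not active" (no number reported)
Compound 3 `COc1ccccc1C1C(C#N)=C(N)N(c2cc(OC)c(OC)c(OC)c2)C2=C1C(=O)CC(C)(C)C2` — 26600 nM

In a functional assay on Ehrlich cells (Mus musculus) for cytotoxicity (a lower number here means a stronger inhibitor, a higher number a weaker inhibitor), compound 3 gives 26600 nM. Compound 3 is the only one of the three with a reported number; for compound 1 and compound 2 this assay records no number at all. Compound 4 `COc1cc(N2C(N)=C(C#N)C(c3ccccc3)C3=C2CC(C)(C)CC3=O)cc(OC)c1OC` is the analogue of compound 3 in which (hydrogen in place of methoxy on an aromatic carbon). Within the data shown here, with no step between measured compounds available, the size of this change cannot be read from the data. The expectation is for a step from compound 3 to compound 4 of a 1.5-fold higher number from compound 3 to compound 4 (0.18 log units; within the scatter), weaker rather than stronger, with a real chance that this assay again reports no number. The estimate for compound 4 is 40000 nM, within a range from 12000 nM to 150000 nM.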

Compound 4, half-maximal inhibitory concentration: "not active" (no number reported)
Compound 4: no number reported; no gap can be computed for the estimate.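

Compound 4 has no number in this assay and compound 3 has one, so no step can be read between compound 3 and compound 4. The compounds shown leave open how far the change from 2-methoxyphenyl to phenyl moves the number. No evidence bears on this result.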